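From Phenyl to Methoxyphenoxy: an Expected Gain in Potency

The source may report more compounds than this note shows. Statements on the series, on what has been measured and on what is new or still open speak of the compounds shown alone.

Compound 2 `O=C(NO)[C@@H]1CSCN1S(=O)(=O)c1ccc(-c2ccccc2)cc1` gives 230 nM in an assay on isolated protein for inhibition of matrix metalloproteinase-9 (Homo sapiens), read by fluorescence, with stated times of 1 h and 30 min (a higher number here means a weaker inhibitor, a lower number a stronger inhibitor), the only full number shown there. Compound 1 `O=C(NO)[C@@H]1CSCN1S(=O)(=O)c1ccc2ccccc2c1` reaches only a limit in this assay, > 50000 nM, and sits at the limit of > 50000 nM in this assay, at which 1 of the 2 values shown sits. Compound 3 `COc1ccc(Oc2ccc(S(=O)(=O)N3CSC[C@H]3C(=O)NO)cc2)cc1` differs from compound 2 by 4-methoxyphenoxy in place of phenyl on an aromatic carbon. Going by the values given here, no measured pair traces this particular change, so nothing fixes its size in advance. The step is nevertheless expected to be a gain in this assay, beyond the scatter, a 12-fold lower number from compound 2 to compound 3 (1.06 log units; beyond the scatter). Compound 3 is therefore estimated at 20 nM, with a range from 3 nM to 150 nM.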

Compound 3, half-maximal inhibitory concentration: 2 nM
Compound 3: middle estimate off by 10-fold (1.00 log units), on the high side; the measured number lies below the stated range.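

Setting 4-methoxyphenoxy in place of phenyl on this aromatic carbon, para to a large group, gives a 120-fold lower number from compound 2 to compound 3 (2.06 log units; beyond the scatter) in this assay. The position therefore accepts the larger group, and this change is now traced by one measured pair. Nothing in the data accounts for the size of the step. The compounds shown leave open which part of the entering group carries the gain, the ether oxygen or the methoxy. As far as these compounds go, whether plain phenoxy, or an amine or carboxylic acid in place of the methoxy, would keep it also remains open.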